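Swapping the side-chain amine for a carbamate

The source may report more compounds than this note shows. Statements on the series, on what has been measured and on what is new or still open speak of the compounds shown alone.

Of the compounds shown here, three sharing one core have been tested in an assay on CHO cells with 5-hydroxytryptamine receptor 1D (Homo sapiens) as the target; a lower number here means a stronger inhibitor, a higher number a weaker inhibitor. Compound 1 `CN(CC1CC1)CC1(O)CCN(CCCc2c[nH]c3ccc(-n4cnnc4)cc23)CC1` gives 1.35 nM, compound 2 `CC(=O)Nc1ccc(CNCC2(O)CCN(CCCc3c[nH]c4ccc(-n5cnnc5)cc34)CC2)cc1` gives 11 nM, and compound 3 `CN(CC(C)(C)C)CC1(O)CCN(CCCc2c[nH]c3ccc(-n4cnnc4)cc23)CC1` gives 1.8 nM. Compound 3 thus stands at the second highest number of the three, close to compound 1 and well apart from compound 2. Compound 4 `CC(C)(C)OC(=O)NCC1(O)CCN(CCCc2c[nH]c3ccc(-n4cnnc4)cc23)CC1` differs from compound 3 by (tert-butoxycarbonyl)amino in place of methyl(neopentyl)amino on a saturated chain carbon bound to a saturated ring carbon. The steps that touch the same position are an 8.1-fold higher number from compound 1 to compound 2 (0.91 log units; beyond the scatter) and a 6.1-fold lower number from compound 2 to compound 3 (0.79 log units; beyond the scatter), both modest. Within the data shown here, no measured step replaces the amine there with a (tert-butoxycarbonyl)amino group, so compound 4 is expected to be a weaker inhibitor, with an estimated step of a 28-fold higher number from compound 3 to compound 4 (1.44 log units; beyond the scatter). Compound 4 is estimated at 50 nM, within 8 nM to 300 nM.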

Compound 4, half-maximal inhibitory concentration: 21 nM
Compound 4: the middle estimate sits 2.4-fold (0.38 log units) above what was measured; low and high end bracket the measured number.
By their numbers in this assay, from the lowest: compounds 1 and 3 (each within the scatter of the next); then compounds 2 and 4 (each within the scatter of the next).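

In this assay, (tert-butoxycarbonyl)amino at this position gives a 12-fold higher number from compound 3 to compound 4 (1.07 log units; beyond the scatter) and a 16-fold higher number from compound 1 to compound 4 (1.19 log units; beyond the scatter), both large. By contrast, a 1.9-fold higher number from compound 2 to compound 4 (0.28 log units; within the scatter) lies within the scatter, so tert-butoxycarbonyl and 4-acetamidobenzyl on that amine nitrogen cannot be told apart here. Nothing available explains these differences.

The compounds shown leave open whether the weaker numbers go with the amide-like carbonyl or with the hydrogen kept on that nitrogen. A urea at this position, or a methyl on the carbamate nitrogen, could help separate the two.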